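From Methoxy to Ethoxy: Estimating Compound 4

The compounds below may be only part of what the source reports. "The series", "measured", "known", "first", "only" and "open" are said of these compounds alone.

Measured compounds:
compound 1 `CCc1ccc(NCN2C(=O)c3ccccc3C2=O)cc1`: 4310 nM
compound 2 `CC(C)c1ccc(NCN2C(=O)c3ccccc3C2=O)cc1`: "not determined" (no result reported)
compound 3 `COc1ccc(NCN2C(=O)c3ccccc3C2=O)cc1`: 470 nM

In an assay on isolated protein for inhibition of ribosomal protein S6 kinase alpha-2 (Homo sapiens), read by fluorescence, with a stated time of 20 min (on this read-out higher numbers stand for weaker inhibition and lower numbers for stronger inhibition), compound 1 gives 4310 nM while compound 3 gives 470 nM; for compound 2 the entry reads "not determined" (no result reported). Among the compounds with values here, compound 3 thus stands lowest of the two numbers, its nearest neighbour being compound 1, the single measured step reading a 9.2-fold lower number from compound 1 to compound 3 (0.96 log units; beyond the scatter).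

Compound 4 `CCOc1ccc(NCN2C(=O)c3ccccc3C2=O)cc1` differs from compound 3 by methyl in place of hydrogen on a saturated chain carbon bound to an oxygen on an aromatic ring. Within the data shown here, no measured step bears on this change: the step of a 9.2-fold lower number from compound 1 to compound 3 (0.96 log units; beyond the scatter) exchanges ethyl for methoxy rather than lengthening an alkoxy chain, and compound 2 offers no number. With nothing to guide a direction, the step from compound 3 to compound 4 is expected to be a 1.3-fold higher number from compound 3 to compound 4 (0.11 log units; within the scatter), none beyond the scatter. Compound 4 is therefore estimated at 600 nM, within 200 nM to 1800 nM.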

Compound 4, half-maximal inhibitory concentration: 590 nM
Compound 4: the middle estimate sits 1.0-fold (0.01 log units) above what was measured; the measured number falls inside the stated range.
By their numbers in this assay, from the lowest: compounds 3 and 4 (each within the scatter of the next); then compound 1.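

Extending methoxy to ethoxy gives a 1.3-fold higher number from compound 3 to compound 4 (0.10 log units; within the scatter) and so no readable change at this position. The advantage over ethyl holds for the longer alkoxy group too, with a 7.3-fold lower number from compound 1 to compound 4 (0.86 log units; beyond the scatter) alongside the earlier step to the methoxy compound. No measured evidence bears on why these groups differ from ethyl. Going by these compounds, whether a longer chain such as propoxy or butoxy would leave the number equally unchanged, or an amine in place of the alkoxy group would keep it, remains open. Steps involving compound 2 cannot be read, so the standing of its isopropyl group is also unsettled.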